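The compounds below may be only part of what the source reports. "The series", "measured", "known", "first", "only" and "open" are said of these compounds alone.

Measured compounds in an assay on Prostate gland for inhibition of steroid 5-alpha-reductase (Rattus norvegicus); on this read-out higher numbers stand for weaker inhibition and lower numbers for stronger inhibition:
compound 1 `CCC(C)n1ccc2cc(/C(C)=C/C(=O)Nc3ccccc3OCCCC(=O)O)ccc21` gives 67 nM
compound 2 `CCCCC(C)n1ccc2cc(/C(C)=C/C(=O)Nc3ccccc3OCCCC(=O)O)ccc21` gives 6 nM
compound 3 `CCCCC(CC)n1ccc2cc(/C(C)=C/C(=O)Nc3ccccc3OCCCC(=O)O)ccc21` gives 7.1 nM

Compound 1 gives the highest number of the three, so on this read-out it is the weakest inhibitor shown. Its nearest neighbour is compound 3, with a 9.4-fold lower number from compound 1 to compound 3 (0.97 log units; beyond the scatter), and its furthest is compound 2, with an 11-fold lower number from compound 1 to compound 2 (1.05 log units; beyond the scatter). Compound 2 and compound 3 themselves differ only by a 1.2-fold higher number from compound 2 to compound 3 (0.07 log units; within the scatter).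

The next compound to consider is compound 4 `C/C(=C\C(=O)Nc1ccccc1OCCCC(=O)O)c1ccc2c(ccn2C(C)c2ccccc2)c1`, which differs from compound 1 by phenyl in place of ethyl on a saturated chain carbon bound to an aromatic nitrogen and a saturated chain carbon. Seen one bond further out, the change reads sec-butyl to 1-phenylethyl: the chain on the aromatic nitrogen grows again, as it did in the two measured steps, though here a ring enters and ethyl leaves rather than hydrogen. Both measured steps that enlarge this chain, an 11-fold lower number from compound 1 to compound 2 (1.05 log units; beyond the scatter) and a 9.4-fold lower number from compound 1 to compound 3 (0.97 log units; beyond the scatter), gave clearly lower numbers. Among the compounds with values here, no measured pair shows an aromatic ring at this position, so the size of the effect is less certain than its direction. On balance a lower number for compound 4 is expected, with the step estimated as a 4.5-fold lower number from compound 1 to compound 4 (0.65 log units; beyond the scatter). Compound 4 is therefore expected to give about 15 nM, within a range from 4 nM to 50 nM.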

Compound 4, half-maximal inhibitory concentration: 19 nM
The estimate for compound 4 lay 1.3-fold (0.10 log units) below the measured number; low and high end bracket the measured number.
By their numbers in this assay, from the lowest: compounds 2 and 3 (each within the scatter of the next); then compound 4; then compound 1.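

A ring can sit on this chain carbon without losing the gain over the smaller sec-butyl group: in this assay, swapping ethyl for phenyl gives a 3.5-fold lower number from compound 1 to compound 4 (0.55 log units; beyond the scatter). Yet phenyl does not match the open saturated chains, with a 3.2-fold higher number from compound 2 to compound 4 (0.50 log units; beyond the scatter) when it replaces butyl and a 2.7-fold higher number from compound 3 to compound 4 (0.43 log units; beyond the scatter) when 1-phenylethyl replaces 1-ethylpentyl, so the number here depends on more than the chain simply growing, and compound 4 sits between compound 1 and the pair of compound 2 and compound 3. Nothing measured here on these compounds accounts for this gap between the phenyl ring and the saturated chains.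

The compounds shown leave open how cyclohexyl, a saturated ring of the same size, would compare with phenyl on this carbon, which would help separate the presence of a ring from its aromatic nature. They also leave open whether a methoxy group or an amine carried on the phenyl ring, or a benzyl group on the aromatic nitrogen, would bring the number closer to that of compound 2.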